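Cytotoxicity of Three Sulfonylguanidines in a Skin Cell Line

This account rests on a few compounds, and the source may have more. Where it says the series, first, only, none or still open, it means among the compounds named here.

Measured compounds:
- compound 1, `Cc1cccc(CSc2cc(Cl)c(C)cc2S(=O)(=O)/N=C(\N)n2nccc2-c2ccccc2)c1`: 10000 nM
- compound 2, `Cc1cc(S(=O)(=O)/N=C(\N)n2nccc2-c2ccccc2)c(SCc2ccccc2C)cc1Cl`: 18000 nM

In an ADME assay on HaCaT cells (Homo sapiens) for cytotoxicity, read by MTT assay, with a stated time of 72 h (on this read-out lower numbers stand for stronger inhibition and higher numbers for weaker inhibition), compound 1 gives 10000 nM and compound 2 gives 18000 nM; the two numbers lie within the scatter of each other, so compound 2 stands alongside compound 1 rather than apart from it. For the measured compounds named here, the only measured step, a 1.8-fold higher number from compound 1 to compound 2 (0.26 log units; within the scatter), moved the methyl group around the same ring without a change beyond the scatter. Compound 3, `Cc1cc(S(=O)(=O)/N=C(\N)n2nccc2-c2ccccc2)c(SCc2cccc(C(F)(F)F)c2)cc1Cl`, differs from compound 2 by 3-(trifluoromethyl)phenyl in place of 2-methylphenyl on a saturated chain carbon bound to a sulfur. Going by the values given here, since the one comparable change left the number within the scatter, the expected step of a 1.2-fold lower number from compound 2 to compound 3 (0.08 log units; within the scatter) is none beyond the scatter. For compound 3 the estimate in this assay is 15000 nM, with a range from 6000 nM to 40000 nM.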

Compound 3, half-maximal inhibitory concentration: 18000 nM
Estimate against measurement, compound 3: 1.2-fold (0.08 log units) below; measured number inside the range.
By their numbers in this assay, from the lowest: compounds 1, 2 and 3 (each within the scatter of the next).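

Putting 3-(trifluoromethyl)phenyl in place of 2-methylphenyl on a saturated chain carbon bound to a sulfur brings no change at the digits printed from compound 2 to compound 3 (within the scatter) in this assay, and trifluoromethyl in place of methyl on an aromatic carbon brings a 1.8-fold higher number from compound 1 to compound 3 (0.26 log units; within the scatter). This place therefore tolerates not only a shift of the methyl group but also its exchange for a trifluoromethyl group, with cytotoxicity in these cells staying within the scatter. Nothing available offers a reason for this flat result. The compounds shown leave open whether an amine, a carboxylic acid or a longer chain in this place would also leave the number within the scatter.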